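Phenyl to pyridin-2-yl on the piperazine nitrogen

The compounds below may be only part of what the source reports. "The series", "measured", "known", "first", "only" and "open" are said of these compounds alone.

Of the compounds shown here, three sharing one core have been measured in a functional assay on the whole organism (blood) with Rattus norvegicus as the target, at a dose of 100 mg/kg by the oral route; on this read-out lower numbers stand for less inhibition and higher numbers for more inhibition at the one dose given (going by the name of the read-out). Compound 1 `N#Cc1ccc(OCC(O)CN2CCN(c3ccc(F)cc3)CC2)cc1` gives 38.6%, compound 2 `N#Cc1ccc(OCC(O)CN2CCN(c3cccc(Cl)c3)CC2)cc1` gives 16.5%, and compound 3 `N#Cc1ccc(OCC(O)CN2CCN(c3ccccc3)CC2)cc1` gives 56.7%. Compound 3 stands highest of the three: the step of a number 18.1 percentage points higher from compound 1 to compound 3 (beyond the scatter) and the step of a number 40.2 percentage points higher from compound 2 to compound 3 (beyond the scatter) both lie beyond the scatter, as does the step of a number 22.1 percentage points lower from compound 1 to compound 2 (beyond the scatter). Compound 4 `N#Cc1ccc(OCC(O)CN2CCN(c3ccccn3)CC2)cc1` differs from compound 3 by pyridin-2-yl in place of phenyl on an amine nitrogen in a ring. Among the measured compounds shown here, none of the measured steps covers this change; they concern only fluoro or chloro on the aromatic ring, and each of those substitutions lowered the read-out relative to the bare phenyl of compound 3. That pattern rests on three compounds only. Since compound 3 is the highest measured point and the two departures from it both went down, a step downward of moderate size is expected, though the data give no direct guide, so the range is kept wide. In this assay compound 4 is estimated at 42%, between 18% and 66%. The estimated step is a number 14.7 percentage points lower from compound 3 to compound 4 (beyond the scatter).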

Compound 4, a percentage reported as inhibition, in the whole organism at one dose (the size of the read-out at that dose, not a potency): 39.6%
The estimate for compound 4 lay 2.4 percentage points above the measured number, and the stated range covers the measured number.
By their numbers in this assay, from the lowest: compound 2; then compounds 1 and 4 (each within the scatter of the next); then compound 3.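

In this assay, replacing the phenyl ring itself with pyridin-2-yl, rather than adding a halogen to it, also brings the read-out down, giving a number 17.1 percentage points lower from compound 3 to compound 4 (beyond the scatter); compounds 1, 2 and 4 all lie under the bare phenyl of compound 3, and none of the four goes against this. Exchanging the substituted rings for pyridin-2-yl gives two different outcomes, with a number 1 percentage points higher from compound 1 to compound 4 (within the scatter) for the 4-fluorophenyl, which cannot be told apart, and a number 23.1 percentage points higher from compound 2 to compound 4 (beyond the scatter) for the 3-chlorophenyl. Nothing available bears on why the read-out moves with this change.

The compounds shown leave open how a pyridin-3-yl, a pyridin-4-yl or a pyrimidin-2-yl on the same amine nitrogen would read. They also leave open how a cyclohexyl group there would compare with the phenyl of compound 3.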